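The source may hold more compounds than are shown below. What is called first, only, known or untested is meant among the compounds shown, and "the series" means these compounds.

Compound 1 `CCCCCOc1ccc2oc(/C=C/[S+](C)[O-])cc(=O)c2c1`: 1600 nM
Compound 2 `Cc1ccc2oc(/C=C/[S+](C)[O-])cc(=O)c2c1`: 1700 nM
Compound 3 `CCCOc1ccc2oc(/C=C/[S+](C)[O-])cc(=O)c2c1`: 1100 nM

These three compounds share one core and were all tested in a functional assay on A549 cells (Homo sapiens) for cytotoxicity, with a stated time of 48 h; on this read-out lower numbers stand for stronger inhibition and higher numbers for weaker inhibition. Compound 3, at 1100 nM, stands level with the other two, since its gaps to both lie within the usual scatter of repeated measurements.

The untested compound 4 `C[S+]([O-])/C=C/c1cc(=O)c2cc(OC(=O)C(C)(C)C)ccc2o1` keeps the core and changes one group, with (tert-butyl)carbonyl in place of propyl on an oxygen on an aromatic ring.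

Going by the values given here, three measured steps bear on this change. Propoxy in place of methyl gave a 1.5-fold lower number from compound 2 to compound 3 (0.19 log units; within the scatter). Shortening the chain gave a 1.5-fold lower number from compound 1 to compound 3 (0.16 log units; within the scatter), and methyl in place of pentyloxy gave a 1.1-fold higher number from compound 1 to compound 2 (0.03 log units; within the scatter). All three stay within the scatter, so among these compounds, changing this group has not yet shifted the number measurably. None of them, however, carries a carbonyl on that oxygen, so the data do not test this new feature directly, and the range must stay wide.

The expected change is a 1.2-fold higher number from compound 3 to compound 4 (0.07 log units; within the scatter), which is an estimate of no real shift beyond the scatter. For compound 4 the estimated value is 1300 nM, with an expected range of 600 nM to 3000 nM.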

Compound 4, half-maximal inhibitory concentration: 1600 nM
For compound 4 the middle estimate is 1.2-fold (0.09 log units) below the measured one; measured number inside the range.
By their numbers in this assay, from the lowest: compounds 3, 1, 4 and 2 (each within the scatter of the next).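

Going by these compounds alone, compound 4 is the only one of the four in which the oxygen on the aromatic ring carries a carbonyl, so this is the first direct test of that feature. In this assay the change of propyl to (tert-butyl)carbonyl gave a 1.5-fold higher number from compound 3 to compound 4 (0.16 log units; within the scatter) and the change of pentyl to the same group gave no change at the digits printed from compound 1 to compound 4 (within the scatter) while ((tert-butyl)carbonyl)oxy in place of methyl gave a 1.1-fold lower number from compound 2 to compound 4 (0.03 log units; within the scatter) and so none of the three comparisons moves the number beyond the scatter, even with a carbonyl and a branched group of 6 heavy atoms at this position. No measurement at hand explains why the number holds so steady here.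

From the compounds shown here alone, the groups compared so far at this position are methyl and the oxygen-linked propyl, pentyl and (tert-butyl)carbonyl, so it remains open whether an amine, a carboxylic acid or a ring attached at the same place would shift the number beyond the scatter. Going by these compounds, it also remains open whether this steadiness extends past these four compounds, or to any read-out other than this single cell assay.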